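Extending a Methoxy Group to Ethoxy

A few compounds are considered here, and "the series" means these few. Any claim that something is new, unique, unknown or untested is made for them only; others in the source may bear on it.

Values in a functional assay on HeLa cells (Homo sapiens) for antiproliferative activity, read by MTT assay, with a stated time of 72 h; a higher number here means a weaker inhibitor, a lower number a stronger inhibitor:
- Compound 1 `COc1cc(C(=O)c2sc3ccccc3c2-c2ccc(F)cc2)cc(OC)c1OC`: 3000 nM
- Compound 2 `COc1ccc(Nc2c(C(=O)c3cc(OC)c(OC)c(OC)c3)sc3ccccc23)cc1`: 7700 nM
- Compound 3 `CCOc1ccc(Nc2c(C(=O)c3cc(OC)c(OC)c(OC)c3)sc3ccccc23)cc1`: not yet measured

Compound 2, at 7700 nM, holds the higher of the two numbers, which makes it the weaker inhibitor of the pair. The move to compound 3 is methyl in place of hydrogen on a saturated chain carbon bound to an oxygen on an aromatic ring. This is methyl in place of hydrogen on a saturated chain carbon bound to an oxygen on an aromatic ring, turning methoxy into ethoxy.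

Within the data shown here, only one measured step bears on this change, and only indirectly. Swapping the 4-fluorophenyl group for a (4-methoxyphenyl)amino group gave a 2.6-fold higher number from compound 1 to compound 2 (0.41 log units; beyond the scatter), a modest step. Among the measured compounds shown here, that exchange replaced a whole group, and no measured pair tests methoxy against ethoxy. The data therefore point to no direction in this assay, and no step beyond the scatter is expected. The estimate stays anchored on compound 2 at 7700 nM.

The expected change is a 1.1-fold lower number from compound 2 to compound 3 (0.04 log units; within the scatter). Compound 3 is estimated at 7000 nM, with an expected range from 3000 nM to 16000 nM.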

Compound 3, half-maximal inhibitory concentration: 700 nM
Compound 3: the middle estimate sits 10-fold (1.00 log units) above what was measured; measured number outside the range, below it.
By their numbers in this assay, from the lowest: compound 3; then compound 1; then compound 2.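

In this assay, one added methyl, turning methoxy into ethoxy, gave an 11-fold lower number from compound 2 to compound 3 (1.04 log units; beyond the scatter), so this saturated chain carbon bound to an oxygen on an aromatic ring proved highly sensitive to a change of a single carbon, something that the earlier whole-group exchange could not reveal. The same change also reversed the standing of the amino-linked group against 4-fluorophenyl: where the first exchange had given a 2.6-fold higher number from compound 1 to compound 2 (0.41 log units; beyond the scatter), the (4-ethoxyphenyl)amino group gave a 4.3-fold lower number from compound 1 to compound 3 (0.63 log units; beyond the scatter), so the outcome of that exchange depends on what the group carries at its far end. Nothing at hand accounts for the size of this gain.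

The compounds shown leave open whether a longer chain such as propoxy, or a branched one such as isopropoxy, would extend the gain or lose it. They also leave open whether the oxygen itself matters, which a plain propyl group in place of the ethoxy group would address, and whether the gain seen in these cells carries over to other cell lines.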